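This account rests on a few compounds, and the source may have more. Where it says the series, first, only, none or still open, it means among the compounds named here.

Values in a functional assay on NCI-H460 cells (Homo sapiens) for inhibition, read by MTT assay, with a stated time of 24 h, tested at 0.1 ug/mL; on this read-out lower numbers stand for less inhibition of growth and higher numbers for more inhibition of growth at the one concentration tested:
compound 1 `O=C(CCCCC(S)CCS)NO`: 5.7%
compound 2 `O=C(CCCCC(S)CCS)Nc1ccccc1`: 5.5%
compound 3 `O=C(CCCCC(S)CCS)Nc1ccccc1Cl`: 6.36%

Compound 2 is not separated from either of the other two measured compounds. The step on one side is a number 0.2 percentage points lower from compound 1 to compound 2 (within the scatter), and the step on the other is a number 0.9 percentage points higher from compound 2 to compound 3 (within the scatter).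

The next compound is compound 4 `O=C(CCCCC(S)CCS)Nc1cccc(Cl)c1`, which differs from compound 2 by one substitution: chloro in place of hydrogen on an aromatic carbon. This is chloro in place of hydrogen on an aromatic carbon, meta to a large group. Among the compounds with values here, the closest precedent is the only measured step of the same kind, a number 0.9 percentage points higher from compound 2 to compound 3 (within the scatter). The replacement of hydroxy by phenyl, a number 0.2 percentage points lower from compound 1 to compound 2 (within the scatter), bears on it only indirectly, as a sign of how little the numbers have moved across the series. Within the data shown here, no measured compound carries chloro at the place it occupies in compound 4, so the precedent is incomplete.

No step beyond the scatter is expected in this assay, in either direction. The estimated step is a number 0.7 percentage points higher from compound 2 to compound 4 (within the scatter). The expected value for compound 4 is 6.2%, within an estimated range of 1% to 15%.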

Compound 4, percent growth inhibition at one concentration: 9.78%
For compound 4 the middle estimate is 3.6 percentage points below the measured one, within the range that was stated.
By their numbers in this assay, from the lowest: compounds 2, 1, 3 and 4 (each within the scatter of the next).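

In this assay, chloro in place of hydrogen on an aromatic carbon, meta to a large group, gives a number 4.3 percentage points higher from compound 2 to compound 4 (within the scatter), so chloro at this place produces no step beyond the scatter. The other chloro step, a number 0.9 percentage points higher from compound 2 to compound 3 (within the scatter), is also within the scatter, and compound 3 at 6.36% and compound 4 at 9.78% lie within the scatter of each other, so this read-out does not tell the two chloro placements apart at the one concentration tested. The data shown offer no measurement that would account for this result.

On these data alone, it remains open whether an amine or a carboxylic acid at this same place would give a step beyond the scatter. It also remains open whether a longer chain in the shared core would separate any of these compounds from compound 2.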